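Fluoro to trifluoromethyl on two related pyridone cores

The source may report more compounds than this note shows. Statements on the series, on what has been measured and on what is new or still open speak of the compounds shown alone.

Measured compounds:
- compound 1, `O=C(Nc1ccc(Oc2ccnc3[nH]ccc23)c(F)c1)c1nn(-c2ccc(Cl)c(F)c2)ccc1=O`: 11600 nM
- compound 2, `O=C(Nc1ccc(Oc2ccnc3[nH]ccc23)c(F)c1)c1nn(-c2ccc(Cl)c(C(F)(F)F)c2)ccc1=O`: 11600 nM
- compound 3, `Cn1ccc2c(Oc3ccc(NC(=O)c4nn(-c5ccc(Cl)c(F)c5)ccc4=O)cc3)ccnc21`: 16800 nM

All three were run in a functional assay on MCF7 cells (Homo sapiens) for cytotoxicity, read by MTT assay, with a stated time of 72 h; a lower number here means a stronger inhibitor, a higher number a weaker inhibitor. Compound 1 and compound 3 share a large part of their structure but differ in more than one place; the difference between the two cores is not broken down here. Their values in this assay lie within the scatter of each other, as do those of compound 2 and compound 3.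

Within the core of compound 1, the change trifluoromethyl in place of fluoro on an aromatic carbon gave no change at the digits printed from compound 1 to compound 2 (within the scatter).

Compound 4, `Cn1ccc2c(Oc3ccc(NC(=O)c4nn(-c5ccc(Cl)c(C(F)(F)F)c5)ccc4=O)cc3)ccnc21`, is not yet measured. It differs from compound 3 by trifluoromethyl in place of fluoro on an aromatic carbon, the same change as that from compound 1 to compound 2, with the same surroundings at the place of change. Since that change gave no change at the digits printed from compound 1 to compound 2 (within the scatter), compound 4 is expected to show about the same step, a 1.1-fold lower number from compound 3 to compound 4 (0.02 log units; within the scatter), from compound 3. The estimate for compound 4 in this assay is 16000 nM, with a range from 7000 nM to 40000 nM.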

Compound 4, half-maximal inhibitory concentration: 15200 nM
Beside the measured number, compound 4's estimate is 1.1-fold (0.02 log units) above it, within the range that was stated.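

In this assay, the change from 4-chloro-3-fluorophenyl to 4-chloro-3-(trifluoromethyl)phenyl on the second core gave a 1.1-fold lower number from compound 3 to compound 4 (0.04 log units; within the scatter). Set beside the earlier step, the change carries from one core to the other with no difference that can be told apart: the same change on two cores in this assay, no change at the digits printed (within the scatter) from compound 1 to compound 2 and a 1.1-fold lower number (0.04 log units; within the scatter) from compound 3 to compound 4, 1.1-fold (0.04 log units) apart, within the scatter of two such steps. This rests on two matched pairs in one cell assay; since both steps lie within the scatter, it shows that the change is silent on these two cores, not that it would be silent on a further core or in another assay, and it gives no reason for the silence.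

On these data alone, only fluoro and trifluoromethyl appear at this place, so it remains open whether a nitrile, a methoxy group, an amine or a carboxylic acid there would move the number in this assay. The two cores differ in more than one place, and no pair shown separates those differences.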